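This account rests on a few compounds, and the source may have more. Where it says the series, first, only, none or still open, it means among the compounds named here.

Measured compounds:
Compound 1, `Cc1nc(N(C)C(=O)NC(=O)c2c(F)cccc2F)sc1C(=O)N/N=C/c1ccc(Cl)cc1`. In a functional assay on HepG2 cells (Homo sapiens) for inhibition, read by MTT assay, with a stated time of 72 h (on this read-out higher numbers stand for weaker inhibition and lower numbers for stronger inhibition), compound 1 gives > 100 ug/mL, which is a limit of the assay and not a number.
Compound 2, `Cc1nc(N(C)C(=O)NC(=O)c2c(F)cccc2F)sc1C(=O)N/N=C/c1ccc(F)cc1`. In this assay compound 2 gives > 100 ug/mL, again a limit.
Compound 3, `CNc1nc(C)c(C(=O)N/N=C/c2ccc(C(F)(F)F)cc2)s1`. In this assay compound 3 gives > 100 ug/mL, also a limit.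

Compound 2 therefore stands nowhere on a numerical scale: only a limit is known for it, and the other two values shown are limits as well, all sitting together (the limit of > 100 ug/mL in this assay, at which 3 of the 3 values shown sit). Among the measured compounds shown here, the one step between compounds differing in a single place, a step that the two limits leave unreadable from compound 1 to compound 2, is unreadable because both ends are limits.

Compound 4, `Cc1nc(N(C)C(=O)NC(=O)c2c(F)cccc2F)sc1C(=O)N/N=C/c1ccc(Cl)cc1Cl`, differs from compound 2 by 2,4-dichlorophenyl in place of 4-fluorophenyl on a carbon with a double bond to nitrogen. For the measured compounds named here, no measured step speaks to this change; the only step available, from compound 1 to compound 2, cannot be sized, and the shared core of compounds 1, 2 and 4 has so far given nothing but limits in this assay. The expectation for compound 4 is accordingly a step that the limit leaves unreadable from compound 2 to compound 4, that is, no readable change beyond the scatter. Compound 4 is estimated at 150 ug/mL, with a range from 60 ug/mL to 400 ug/mL, and most likely the assay will again report only a limit.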

Compound 4, half-maximal inhibitory concentration: 70 ug/mL
The estimate for compound 4 lay 2.1-fold (0.33 log units) above the measured number, and the stated range covers the measured number.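

With 2,4-dichlorophenyl on the carbon with a double bond to nitrogen, the shared core gives a number in this assay, and compound 4 alone among the compounds shown reads 70 ug/mL. Set against the 4-fluorophenyl group, this change gives an at least 1.4-fold lower number from compound 2 to compound 4 (0.15 log units; that floor lies within the scatter), and chloro in place of hydrogen on an aromatic carbon gives an at least 1.4-fold lower number from compound 1 to compound 4 (0.15 log units; that floor lies within the scatter). Because the values on the other side of these comparisons are limits, each step is only a floor and its full size cannot be read, while the steps between two limits cannot be read at all: the limit of > 100 ug/mL in this assay, at which 3 of the 4 values shown sit.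

The compounds shown leave open how far the number for compound 4 truly lies from those of compound 1 and compound 2, and so whether the added chloro makes any change beyond the scatter. They also leave open what a methoxy group, an amine or a carboxylic acid in place of that added chloro would give on the same core in this assay.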